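Ortho fluoro in place of bromo on the isoxazole aryl

The source may report more compounds than this note shows. Statements on the series, on what has been measured and on what is new or still open speak of the compounds shown alone.

Compound 3 `O=[N+]([O-])c1ccc(CN2CCC(n3cc(CC(OCc4cc(-c5ccccc5Br)no4)c4ccc(Br)cc4)nn3)CC2)cc1`, the 2-bromophenyl member of this small series, gives only a limit in a functional assay on MDA-MB-468 cells (Homo sapiens) for cytotoxicity, with a stated time of 48 h; a lower number here means a stronger inhibitor, a higher number a weaker inhibitor: its value of > 25000 nM is an assay limit, not a number (the limit of > 25000 nM in this assay, at which 1 of the 3 values shown sits). Its two neighbours carry fluorine instead: compound 1 `O=[N+]([O-])c1ccc(CN2CCC(n3cc(CC(OCc4cc(-c5ccc(F)cc5)no4)c4ccc(Br)cc4)nn3)CC2)cc1`, with 4-fluorophenyl, gives 4000 nM in this assay, and compound 2 `O=[N+]([O-])c1ccc(CN2CCC(n3cc(CC(OCc4cc(-c5cccc(F)c5)no4)c4ccc(Br)cc4)nn3)CC2)cc1`, with 3-fluorophenyl, gives 3000 nM. The step of a 1.3-fold lower number from compound 1 to compound 2 (0.12 log units; within the scatter) stays within the scatter, whereas the steps of an at least 6.2-fold higher number from compound 1 to compound 3 (0.79 log units; beyond the scatter) and an at least 8.3-fold higher number from compound 2 to compound 3 (0.92 log units; beyond the scatter) are both beyond it.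

Compound 4 `O=[N+]([O-])c1ccc(CN2CCC(n3cc(CC(OCc4cc(-c5ccccc5F)no4)c4ccc(Br)cc4)nn3)CC2)cc1` differs from compound 3 by fluoro in place of bromo on an aromatic carbon. Among the measured compounds shown here, no measured step exchanges bromo for fluoro at the same place; the two steps that reach compound 3 change both the halogen and its place, so they bear only loosely on this one. Since compounds 1 and 2 with fluorine sit well below the limit, compound 4 is expected to return a number, with an estimated step of an at least 2.0-fold lower number from compound 3 to compound 4 (0.31 log units; beyond the scatter). Compound 4 is therefore estimated at 12000 nM in this assay, within 3000 nM to 40000 nM.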

Compound 4, half-maximal inhibitory concentration: 4000 nM
Beside the measured number, compound 4's estimate is 3.0-fold (0.48 log units) above it, and the stated range covers the measured number.
By their numbers in this assay, from the lowest: compounds 2, 1 and 4 (each within the scatter of the next). At a limit, above all of these: compound 3.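

Among the compounds shown here, the exchange of bromo for fluoro on this aromatic carbon, ortho to a large group, gives the first direct reading of this change, and it is an at least 6.2-fold lower number from compound 3 to compound 4 (0.79 log units; beyond the scatter). Where the fluorine sits on the phenyl ring makes no difference that can be read here, as a 1.3-fold higher number from compound 2 to compound 4 (0.12 log units; within the scatter) and no change at the digits printed from compound 1 to compound 4 (within the scatter) both stay within the scatter, so among these compounds the loss goes with 2-bromophenyl and not with a halogen ortho to a large group as such. The first step is only a lower bound, as compound 3 stands at a limit and not at a number: the limit of > 25000 nM in this assay, at which 1 of the 4 values shown sits.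

The compounds shown leave open how 2-chlorophenyl or 2-methylphenyl would read in this assay. They also leave open whether 3-bromophenyl or 4-bromophenyl would stay with the fluorinated compounds or reach the limit.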